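Cytotoxicity notes on a dienone series

The source may report more compounds than this note shows. Statements on the series, on what has been measured and on what is new or still open speak of the compounds shown alone.

Measured so far:
compound 1 `COc1ccc(/C=C/C(=O)/C(C)=C/c2ccc([N+](=O)[O-])cc2)cc1`: 172000 nM
compound 2 `C/C(=C\c1ccc([N+](=O)[O-])cc1)C(=O)/C=C/c1ccc([N+](=O)[O-])cc1`: 32500 nM
compound 3 `C/C(=C\c1ccc([N+](=O)[O-])cc1)C(=O)/C=C/c1ccc(N(C)C)cc1`: 25900 nM

All three numbers come from an ADME assay on LLC-MK2 cells (Macaca mulatta) for cytotoxicity, read by MTT assay, with a stated time of 48 h; on this read-out lower numbers stand for higher toxicity in this test and higher numbers for lower toxicity in this test. Compound 1 stands highest of the three; the steps of a 5.3-fold lower number from compound 1 to compound 2 (0.72 log units; beyond the scatter) and a 6.6-fold lower number from compound 1 to compound 3 (0.82 log units; beyond the scatter) are both beyond the scatter, whereas a 1.3-fold lower number from compound 2 to compound 3 (0.10 log units; within the scatter) lies within it.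

Compound 4 `COc1ccc(/C=C/C(=O)/C(C)=C/c2ccc(N(C)C)cc2)cc1` is not yet measured in this assay. It differs from compound 1 by dimethylamino in place of nitro on an aromatic carbon. The same change is made from compound 2 to compound 3: dimethylamino in place of nitro on an aromatic carbon. The two cores differ only by methoxy in place of nitro on an aromatic carbon; the place of the change is the same in both pairs.

Resting on the step of a 1.3-fold lower number from compound 2 to compound 3 (0.10 log units; within the scatter), compound 4 is expected to sit close to compound 1, with an estimated step of a 1.3-fold lower number from compound 1 to compound 4 (0.11 log units; within the scatter). Compound 4 is therefore estimated at 135000 nM, expected between 60000 nM and 260000 nM.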

Compound 4, half-maximal cytotoxic concentration: 285000 nM
Compound 4: the middle estimate sits 2.1-fold (0.32 log units) below what was measured; measured number above the stated range.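

In this assay, dimethylamino in place of nitro on the core of compound 1 gives a 1.7-fold higher number from compound 1 to compound 4 (0.22 log units; within the scatter). Set beside the same change on the core of compound 2, the two steps do not differ: the same change on two cores in this assay, a 1.3-fold lower number (0.10 log units; within the scatter) from compound 2 to compound 3 and a 1.7-fold higher number (0.22 log units; within the scatter) from compound 1 to compound 4, 2.1-fold (0.32 log units) apart, within the scatter of two such steps. The change therefore moves the number beyond the scatter on neither core, but two pairs do not show that this holds on any other core in the series.

The compounds shown leave open how a carboxylic acid or a chlorine atom would behave at the same place on the aromatic ring. Also open, from the compounds shown here alone, is whether a longer chain in place of the methyl group on the shared core would alter these steps.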